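This account rests on a few compounds, and the source may have more. Where it says the series, first, only, none or still open, it means among the compounds named here.

Measured so far in an assay on U2OS cells for activation of nuclear factor erythroid 2-related factor 2 (Homo sapiens), read by beta-arrestin recruitment, with a stated time of 6 h; a lower number here means that less compound is needed, a higher number that more compound is needed for the effect:
- compound 1, `O=S(=O)(/C=C\c1ncccc1F)c1ccccc1F`, gives 482 nM
- compound 2, `O=S(=O)(/C=C\c1ncccc1Cl)c1ccccc1F`, gives 1030 nM

For the measured compounds named here, compound 2 has the higher of the two numbers, with a 2.1-fold higher number from compound 1 to compound 2 (0.33 log units; beyond the scatter) the only step measured. Compound 3, `O=S(=O)(/C=C\c1ncccc1Cl)c1ccccc1Cl`, differs from compound 2 by chloro in place of fluoro on an aromatic carbon, on an aromatic carbon ortho to a large group. Going by the values given here, the one measured step involved the same exchange of chloro for fluoro and went up modestly, so a rise of like size is expected, given as a 1.8-fold higher number from compound 2 to compound 3 (0.27 log units; within the scatter). Compound 3 is therefore expected to give about 1900 nM in this assay, within roughly 700 nM to 5000 nM.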

Compound 3, half-maximal effective concentration: 1100 nM
Compound 3: the middle estimate sits 1.7-fold (0.24 log units) above what was measured, and the stated range covers the measured number.
By their numbers in this assay, from the lowest: compound 1; then compounds 2 and 3 (each within the scatter of the next).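

On the aromatic carbon ortho to a large group, in the six-membered aromatic ring of carbon only, chloro in place of fluoro gives a 1.1-fold higher number from compound 2 to compound 3 (0.03 log units; within the scatter) in this assay. At this position, the exchange therefore cannot be told apart from the usual scatter, whereas the same exchange at the other place, a 2.1-fold higher number from compound 1 to compound 2 (0.33 log units; beyond the scatter), lay beyond it. No evidence is available to explain this result. The compounds shown leave open whether a methoxy group, an amine or a nitrile at this position would move the number beyond the scatter.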